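Chloro on the fused ring of compound 1: cytotoxicity outlook

The source may report more compounds than this note shows. Statements on the series, on what has been measured and on what is new or still open speak of the compounds shown alone.

Compound 1 `CC(=O)OC[C@H]1O[C@@H](CC(=O)/C=C2\C(=O)N(Cc3ccccc3)c3ccccc32)[C@H](OC(C)=O)[C@@H](OC(C)=O)[C@@H]1OC(C)=O` gives 71200 nM in an ADME assay on Vero cells (Chlorocebus sabaeus) for cytotoxicity, read by resazurin assay, with a stated time of 72 h; on this read-out higher numbers stand for lower toxicity in this test and lower numbers for higher toxicity in this test; compound 2 `CC(=O)OC[C@H]1O[C@@H](CC(=O)/C=C2\C(=O)N(Cc3ccc(Br)cc3)c3ccccc32)[C@H](OC(C)=O)[C@@H](OC(C)=O)[C@@H]1OC(C)=O` gives 76500 nM and compound 3 `CC(=O)OC[C@H]1O[C@@H](CC(=O)/C=C2\C(=O)Nc3ccccc32)[C@H](OC(C)=O)[C@@H](OC(C)=O)[C@@H]1OC(C)=O` gives 127000 nM, both within the scatter of compound 1. The steps of a 1.1-fold higher number from compound 1 to compound 2 (0.03 log units; within the scatter), a 1.8-fold higher number from compound 1 to compound 3 (0.25 log units; within the scatter) and a 1.7-fold higher number from compound 2 to compound 3 (0.22 log units; within the scatter) all stay within the scatter. Compound 4 `CC(=O)OC[C@H]1O[C@@H](CC(=O)/C=C2\C(=O)N(Cc3ccccc3)c3ccc(Cl)cc32)[C@H](OC(C)=O)[C@@H](OC(C)=O)[C@@H]1OC(C)=O` differs from compound 1 by chloro in place of hydrogen on an aromatic carbon. Going by the values given here, the nearest precedent is the halogen added from compound 1 to compound 2, which did not move the number, so no step beyond the scatter is expected. Compound 4 is estimated at 75000 nM, with a range of 38000 nM to 150000 nM. The expected step is a 1.1-fold higher number from compound 1 to compound 4 (0.02 log units; within the scatter).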

Compound 4, half-maximal cytotoxic concentration: 91200 nM
Beside the measured number, compound 4's estimate is 1.2-fold (0.08 log units) below it; low and high end bracket the measured number.
By their numbers in this assay, from the lowest: compounds 1, 2, 4 and 3 (each within the scatter of the next).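

Chloro on an aromatic carbon of the six-membered ring that is part of the fused system gives a 1.3-fold higher number from compound 1 to compound 4 (0.11 log units; within the scatter) in this assay, so this position on the core of compound 1 takes a halogen with no step beyond the scatter. The earlier halogen sat on the benzyl group, as the 4-bromobenzyl of compound 2, so the fused ring now has its own reading. No measurement shown here bears on this result.

As far as these compounds go, whether an amine or a carboxylic acid at this position would also stay within the scatter remains open. Also open, from the compounds shown here alone, is whether chloro behaves the same way on compound 3, which carries the amide hydrogen in place of benzyl.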